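Dimethylamino for acetyl on the pendant phenyl ring

The compounds below may be only part of what the source reports. "The series", "measured", "known", "first", "only" and "open" are said of these compounds alone.

Measured so far in a functional assay on OVCAR-3 cells (Homo sapiens) for inhibition, read by sulforhodamine B assay, with a stated time of 48 h; a lower number here means a stronger inhibitor of growth, a higher number a weaker inhibitor of growth:
compound 1, `COc1cc(C)cc(-c2c(-c3ccnc(-c4ccc(C(C)=O)cc4)c3)cnn2CC#N)c1`, 2610 nM
compound 2, `COc1cc(C)cc(-c2nn(CC#N)cc2-c2ccc(-c3cccc(C(C)=O)c3)nc2)c1`, 1340 nM
compound 3, `COc1cc(C)cc(-c2nn(CC#N)cc2-c2ccnc(-c3ccc(N(C)C)cc3)c2)c1`, 204 nM

Compound 1 carries the highest number of the three. Compound 2 sits within the scatter of compound 1, so no order between the two can be read. Compound 3 lies beyond the scatter, with a number well below that of compound 1; it differs from compound 1 in more than one place, so only the two values themselves can be compared.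

Compound 4, `COc1cc(C)cc(-c2c(-c3ccnc(-c4ccc(N(C)C)cc4)c3)cnn2CC#N)c1`, has not yet been run in this assay. It differs from compound 1 in one place: dimethylamino in place of acetyl on an aromatic carbon. Among the measured compounds shown here, no pair of measured compounds shows this change alone, so its size has to be estimated. The expectation is a step toward a lower number, beyond the scatter, of about a 4.7-fold lower number from compound 1 to compound 4 (0.68 log units; beyond the scatter), leaning on compound 3, which carries the same entering group and gives 204 nM. Compound 4 is therefore estimated at 550 nM, with a range from 150 nM to 2000 nM.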

Compound 4, concentration for 50% growth inhibition: 30 nM
Compound 4: the middle estimate sits 18-fold (1.26 log units) above what was measured, outside the stated range (below it).
By their numbers in this assay, from the lowest: compound 4; then compound 3; then compounds 2 and 1 (each within the scatter of the next).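

Among the compounds shown here, on the core of compound 1, the swap of 4-acetylphenyl to 4-(dimethylamino)phenyl gives in this assay an 87-fold lower number from compound 1 to compound 4 (1.94 log units; beyond the scatter) and is the first change that can be read alone. The position on the aromatic carbon para to a large group is therefore highly sensitive to the group it carries, even though the leaving and entering groups have the same count of heavy atoms and neither adds a ring or a net charge. Nothing measured alongside these values accounts for the size of the step.

As far as these compounds go, it remains open whether the gain holds for a smaller amine such as methylamino, or for a ring amine such as morpholine or piperidine. A methoxy group or a carboxylic acid at the same place would show how far the value depends on an amine at all.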